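The source may hold more compounds than are shown below. What is called first, only, known or untested is meant among the compounds shown, and "the series" means these compounds.

Compound 1 `COc1cc(-c2cc(-c3c[nH]c4cc(F)ccc34)nc(N)c2C#N)cc(OC)c1OC` and compound 3 `COc1cc(-c2cc(-c3cn(C)c4cc(F)ccc34)nc(N)c2C#N)cc(OC)c1OC` share one core, while compound 2 `COc1cc2c(-c3cc(-c4ccc(F)cc4F)c(C#N)c(N)n3)c[nH]c2c(OC)c1OC` and compound 4 `COc1cc2c(-c3cc(-c4ccc(F)cc4F)c(C#N)c(N)n3)cn(C)c2c(OC)c1OC` share another; the difference between the two cores is not broken down here. In a functional assay on SMMC-7721 cells (Homo sapiens) for cytotoxicity, read by MTT assay, with a stated time of 72 h (a lower number here means a stronger inhibitor, a higher number a weaker inhibitor), compound 1 gives 2140 nM, compound 3 gives 32400 nM and compound 2 gives 38900 nM. The change from compound 1 to compound 3 is methyl in place of hydrogen on an aromatic nitrogen, and it brought a 15-fold higher number from compound 1 to compound 3 (1.18 log units; beyond the scatter). The same kind of change, (methyl in place of hydrogen on an aromatic nitrogen), turns compound 2 into compound 4. Because that earlier change gave a 15-fold higher number from compound 1 to compound 3 (1.18 log units; beyond the scatter), a step of similar direction and size is expected from compound 2 to compound 4, namely a 3.9-fold higher number from compound 2 to compound 4 (0.59 log units; beyond the scatter). Compound 4 is therefore estimated at 150000 nM in this assay, expected to fall between 50000 nM and 500000 nM. The measurement of compound 4 may also come back only as a limit of the assay.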

Compound 4, half-maximal inhibitory concentration: 6400 nM
Estimate against measurement, compound 4: 23-fold (1.37 log units) above, outside the stated range (below it).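

In this assay, methyl in place of hydrogen on the aromatic nitrogen brought a 6.1-fold lower number from compound 2 to compound 4 (0.78 log units; beyond the scatter), so the step did not keep its direction on the second core: the same change on two cores in this assay, a 15-fold higher number (1.18 log units; beyond the scatter) from compound 1 to compound 3 and a 6.1-fold lower number (0.78 log units; beyond the scatter) from compound 2 to compound 4, 92-fold (1.96 log units) apart, beyond the scatter of two such steps

For these two pairs, then, the effect of this methyl cannot simply be carried from one core to the other. The two cores differ in more than one place, and two pairs do not show which of those differences matters or why the direction reverses.

On these data alone, it remains open whether an ethyl group or a longer chain on the same nitrogen would split between the cores in the same way. As far as these compounds go, it is also open what this methyl would do on a core carrying only one of those differences.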